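Compound 3 to compound 4: a pyridine group enters

The source may report more compounds than this note shows. Statements on the series, on what has been measured and on what is new or still open speak of the compounds shown alone.

In a toxicity assay on MT4 cells (Homo sapiens) for cytotoxicity, read by MTT assay, with a stated time of 5 days (a lower number here means that less compound is tolerated, a higher number that more compound is tolerated), compound 1 (`Cc1cc(-c2ccco2)cc(C)c1Nc1ccnc(Nc2ccc(C#N)cc2)n1`) carries furan-2-yl and gives 1700 nM as the lowest number. Compound 2 (`Cc1cc(-c2cc3ccccc3s2)cc(C)c1Nc1ccnc(Nc2ccc(C#N)cc2)n1`) carries 1-benzothiophen-2-yl and gives 138000 nM as the highest. Compound 3 (`Cc1csc(-c2cc(C)c(Nc3ccnc(Nc4ccc(C#N)cc4)n3)c(C)c2)c1`) carries 4-methylthiophen-2-yl and stands second highest at 34000 nM of the three.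

Compound 4 (`Cc1cc(-c2cc(C)c(Nc3ccnc(Nc4ccc(C#N)cc4)n3)c(C)c2)ccn1`) has 2-methylpyridin-4-yl in place of 4-methylthiophen-2-yl on an aromatic carbon.

Exchanges at this place have moved the number strongly: the large 81-fold higher number from compound 1 to compound 2 (1.91 log units; beyond the scatter) and the large 20-fold higher number from compound 1 to compound 3 (1.30 log units; beyond the scatter) stand against the modest 4.1-fold lower number from compound 2 to compound 3 (0.61 log units; beyond the scatter) among the measured compounds. Going by the values given here, no measured compound carries 2-methylpyridin-4-yl, so these steps show the size a change here can reach but not its direction. The one weak pointer is that compound 2 and compound 3 contain sulfur and stand above compound 1, which contains none. Compound 4 also lacks sulfur, though three compounds carry little weight. A modest step towards a lower number is therefore expected in this assay and is estimated as a 2.8-fold lower number from compound 3 to compound 4 (0.45 log units; beyond the scatter) with wide uncertainty. For compound 4 the expected value is 12000 nM within an estimated range (3000 nM to 50000 nM).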

Compound 4, half-maximal cytotoxic concentration: 4900 nM
Compound 4: the middle estimate sits 2.4-fold (0.39 log units) above what was measured; measured number inside the range.
By their numbers in this assay, from the lowest: compound 1; then compound 4; then compound 3; then compound 2.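

In this assay, the exchange of 4-methylthiophen-2-yl for 2-methylpyridin-4-yl gives a 6.9-fold lower number from compound 3 to compound 4 (0.84 log units; beyond the scatter), while the exchange of 1-benzothiophen-2-yl for the same group gives a 28-fold lower number from compound 2 to compound 4 (1.45 log units; beyond the scatter), and the exchange of furan-2-yl for it gives a 2.9-fold higher number from compound 1 to compound 4 (0.46 log units; beyond the scatter). The split seen earlier now holds across four compounds, with sulfur-free compound 1 and compound 4 below sulfur-bearing compound 3 and compound 2, yet the two sulfur-free compounds still differ beyond the scatter, so absence of sulfur does not fix the number. Ring size does not order the series either, as the five-membered aromatic rings of compound 1 and compound 3 stand on opposite sides of the six-membered ring of compound 4, and no measurement in hand accounts for these differences.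

The compounds shown do not separate the contribution of the ring nitrogen from that of the methyl group in 2-methylpyridin-4-yl, a comparison that unsubstituted pyridin-4-yl and a plain phenyl ring would address. On these data alone, how an amine or a carboxylic acid at this place would fall relative to these four numbers also remains open.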